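Swapping the thiophene ring for a fluorinated phenyl ring

This account rests on a few compounds, and the source may have more. Where it says the series, first, only, none or still open, it means among the compounds named here.

Compound 3 `c1cn2cc(-c3ccsc3)nc(-c3ccc4ncn(C5CCCCC5)c4c3)c2n1` gives 15.4% in a functional assay on KM12 cells (Homo sapiens) for inhibition, read by sulforhodamine B assay, with a stated time of 48 h, tested at 10 uM (on this read-out higher numbers stand for more inhibition at the one concentration tested (going by the name of the read-out) and lower numbers for less inhibition), the lowest of the three numbers measured. Compound 1 `c1ccc(-c2cn3ccnc3c(-c3ccc4ncn(C5CCCCC5)c4c3)n2)cc1` gives 49% and compound 2 `COc1ccc(-c2cn3ccnc3c(-c3ccc4ncn(C5CCCCC5)c4c3)n2)cc1` gives 83.2% in this assay. The measured steps are a number 34.2 percentage points higher from compound 1 to compound 2 (beyond the scatter), a number 33.6 percentage points lower from compound 1 to compound 3 (beyond the scatter) and a number 67.8 percentage points lower from compound 2 to compound 3 (beyond the scatter). Compound 4 `Fc1ccccc1-c1cn2ccnc2c(-c2ccc3ncn(C4CCCCC4)c3c2)n1` carries 2-fluorophenyl in place of thiophen-3-yl on an aromatic carbon. Going by the values given here, the step most directly bearing on this change is the large drop seen when thiophen-3-yl replaced phenyl, which compound 4 undoes; no measured step shows the effect of a fluorine on the phenyl ring, and the methoxy step concerns a different group. Compound 4 is therefore expected to return roughly to the level of compound 1. The expected step is a number 34.6 percentage points higher from compound 3 to compound 4 (beyond the scatter), a large rise. Compound 4 is estimated at 50%, between 25% and 75%.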

Compound 4, a percentage reported as inhibition, at one concentration (the size of the read-out at that concentration, not a potency): 2.45%
Estimate against measurement, compound 4: 47.6 percentage points above; measured number below the stated range.
By their numbers in this assay, from the lowest: compound 4; then compound 3; then compound 1; then compound 2.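

At this position in this assay, adding a fluoro to the phenyl ring does not preserve the level of the unsubstituted phenyl, giving a number 46.6 percentage points lower from compound 1 to compound 4 (beyond the scatter), and 2-fluorophenyl in place of thiophen-3-yl gives a number 13 percentage points lower from compound 3 to compound 4 (beyond the scatter). Substitution on the phenyl ring can thus move the number in either direction, with 2-fluorophenyl in place of 4-methoxyphenyl giving a number 80.8 percentage points lower from compound 2 to compound 4 (beyond the scatter). No available evidence accounts for these differences.

The compounds shown leave open whether the fall belongs to fluorine itself or to where it sits, and how an amine on the phenyl ring would compare.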